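Cinnamamide Triazoles: Cytotoxicity on Vero Cells

The source may hold more compounds than are shown below. What is called first, only, known or untested is meant among the compounds shown, and "the series" means these compounds.

Measured compounds:
compound 1, `O=C(/C=C/c1ccc([N+](=O)[O-])s1)Nc1nnc(-c2ccccc2)[nH]1`: 1670000 nM
compound 2, `C=C(C)COc1ccc(/C=C/C(=O)Nc2nnc(-c3ccccc3)[nH]2)cc1`: 1420000 nM

Both share a cinnamamide core linked to a triazole. In an ADME assay on Vero cells (Chlorocebus sabaeus) for cytotoxicity, read by MTT assay, with a stated time of 72 h (on this read-out higher numbers stand for lower toxicity in this test and lower numbers for higher toxicity in this test), compound 1 gives 1670000 nM, and compound 2 gives 1420000 nM. The two numbers lie within the usual scatter of each other, so neither can be said to differ from the other in this assay.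

Compound 3, `COc1ccc(/C=C/C(=O)Nc2nnc(-c3ccccc3)[nH]2)cc1`, has not yet been measured. It differs from compound 2 by hydrogen in place of 1-methylethenyl on a saturated chain carbon bound to an oxygen on an aromatic ring. Going by the values given here, no comparable step between measured compounds is available, so for this change a step of none beyond the scatter is expected. The step of a 1.0-fold lower number from compound 2 to compound 3 (0.01 log units; within the scatter) is expected to stay within the scatter. Compound 3 is therefore estimated at 1400000 nM, with a range from 700000 nM to 2800000 nM.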

Compound 3, half-maximal cytotoxic concentration: 1280000 nM
Compound 3: middle estimate off by 1.1-fold (0.04 log units), on the high side; the measured number falls inside the stated range.
By their numbers in this assay, from the lowest: compounds 3, 2 and 1 (each within the scatter of the next).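

Replacing (2-methylprop-2-en-1-yl)oxy with methoxy in this assay gives a 1.1-fold lower number from compound 2 to compound 3 (0.05 log units; within the scatter) and so leaves the number unchanged within the scatter, which means that the 1-methylethenyl part of this chain has no readable effect here. Placing 4-methoxyphenyl where 5-nitrothiophen-2-yl stood gives a 1.3-fold lower number from compound 1 to compound 3 (0.12 log units; within the scatter) and likewise cannot be told apart from repeat measurements. No measured evidence that could explain these results is available.

Still open, from the compounds shown here alone, is whether an amine or a carboxylic acid in place of the methoxy group would move the number beyond the scatter.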